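Swapping trifluoromethyl for a sulfonate on a thiourea antagonist

The compounds below may be only part of what the source reports. "The series", "measured", "known", "first", "only" and "open" are said of these compounds alone.

Two related thioureas have been tested in a functional assay for antagonist activity at Vanilloid receptor (Rattus norvegicus); on this read-out lower numbers stand for stronger inhibition and higher numbers for weaker inhibition. Compound 1, with the structure `COc1cc(C/N=C(\S)NCc2ccc(C(C)(C)C)cc2)ccc1OS(C)(=O)=O`, gives 300 nM in this assay. Compound 2, with the structure `CC(C)(C)c1ccc(C/N=C(\S)NCc2ccc(C(F)(F)F)cc2)cc1`, gives 12400 nM in this assay, the higher of the two numbers, and the gap between compound 1 and compound 2 lies beyond the scatter of repeated measurements. Compound 3, with the structure `CC(C)(C)c1ccc(C/N=C(\S)NCc2ccc(OS(C)(=O)=O)cc2)cc1`, has not yet been measured. Compound 3 differs from compound 2 in one place: (methylsulfonyl)oxy in place of trifluoromethyl on an aromatic carbon. For the measured compounds named here, the same (methylsulfonyl)oxy group appears in compound 1, although on a ring that also bears a methoxy, so no measured pair shows this change on its own. The estimated step from compound 2 to compound 3 in this assay is an 8.3-fold lower number from compound 2 to compound 3 (0.92 log units; beyond the scatter), a move toward stronger inhibition. For compound 3 the expected value in this assay is 1500 nM, with a range from 300 nM to 7000 nM.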

Compound 3, half-maximal inhibitory concentration: 9300 nM
For compound 3 the middle estimate is 6.2-fold (0.79 log units) below the measured one, outside the stated range (above it).
By their numbers in this assay, from the lowest: compound 1; then compounds 3 and 2 (each within the scatter of the next).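

Putting (methylsulfonyl)oxy in place of trifluoromethyl gives a 1.3-fold lower number from compound 2 to compound 3 (0.12 log units; within the scatter) in this assay. At this place, para to a large group, the two groups cannot be told apart on this read-out, even though the entering group counts 3 hydrogen-bond acceptors and the leaving group counts none. The (methylsulfonyl)oxy group on its own therefore does not bring compound 3 into line with compound 1 at 300 nM on a ring that also bears a methoxy.

Nothing available explains why this swap leaves the number within the scatter. Still open, from the compounds shown here alone, is whether a methoxy added to the ring of compound 3 would lower its number, and whether an amine or a carboxylic acid at this place would move the number at all.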